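The compounds below may be only part of what the source reports. "The series", "measured", "known", "first", "only" and "open" are said of these compounds alone.

Compound 1 `COc1cc2c(Oc3c(F)cc(NC(=O)NN4C(=O)CSC4c4c(F)cccc4F)cc3F)ccnc2cc1OCCCN1CCc2sccc2C1` gives > 20000 nM in a functional assay on A549 cells (Homo sapiens) for antiproliferative activity, read by MTT assay, with a stated time of 72 h (on this read-out higher numbers stand for weaker inhibition and lower numbers for stronger inhibition), and that value is a limit of the assay, not a number. Compound 2 `COc1cc2c(Oc3c(F)cc(NC(=O)NN4C(=O)CSC4c4c(F)cccc4F)cc3F)ccnc2cc1OCCCN1CCC(C)CC1` gives 970 nM in this assay. Compound 3 `COc1cc2c(Oc3c(F)cc(NC(=O)NN4C(=O)CCSC4c4c(F)cccc4F)cc3F)ccnc2cc1OCCCN1CCc2sccc2C1` gives > 20000 nM in this assay, again a limit rather than a number.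

Compound 1 and compound 2 differ in one place: a group of 7 heavy atoms (6 carbon, 1 nitrogen; one six-membered non-aromatic ring with 1 hetero atom) in place of a group of 9 heavy atoms (7 carbon, 1 nitrogen, 1 sulfur; one five-membered aromatic ring with 1 hetero atom, one six-membered non-aromatic ring with 1 hetero atom), on a saturated chain carbon, three bonds along the chain from an oxygen on an aromatic ring. That change made an at least 20-fold lower number from compound 1 to compound 2 (1.31 log units; beyond the scatter), a step whose true size is hidden because the limit of > 20000 nM in this assay, at which 2 of the 3 values shown sit, holds the starting value. The difference between the core of compound 1 and the core of compound 3 is not broken down here. Compound 4 `COc1cc2c(Oc3c(F)cc(NC(=O)NN4C(=O)CCSC4c4c(F)cccc4F)cc3F)ccnc2cc1OCCCN1CCC(C)CC1` has not been measured; it stands to compound 3 as compound 2 stands to compound 1, the same change: a group of 7 heavy atoms (6 carbon, 1 nitrogen; one six-membered non-aromatic ring with 1 hetero atom) in place of a group of 9 heavy atoms (7 carbon, 1 nitrogen, 1 sulfur; one five-membered aromatic ring with 1 hetero atom, one six-membered non-aromatic ring with 1 hetero atom), on a saturated chain carbon, three bonds along the chain from an oxygen on an aromatic ring. Since compound 3 sits at a limit, the step to compound 4 is expected to be at least an at least 8.0-fold lower number from compound 3 to compound 4 (0.90 log units; beyond the scatter), by analogy with the earlier step, and compound 4 is estimated at 2500 nM.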

Compound 4, half-maximal inhibitory concentration: 1630 nM
The estimate for compound 4 lay 1.5-fold (0.19 log units) above the measured number, within the range that was stated.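

The change to 4-methylpiperidin-1-yl gave an at least 12-fold lower number from compound 3 to compound 4 (1.08 log units; beyond the scatter) in this assay. It therefore carried over in direction from the core of compound 1 to the core of compound 3, on the evidence of just these two cores, and both steps are large: the same change on two cores in this assay, an at least 20-fold lower number (1.31 log units; beyond the scatter) from compound 1 to compound 2 and an at least 12-fold lower number (1.08 log units; beyond the scatter) from compound 3 to compound 4; the limit leaves it open whether they differ. Both steps start from a limit of the assay, so their true sizes stay hidden and it cannot be said whether the core alters the size of the effect: the limit of > 20000 nM in this assay, at which 2 of the 4 values shown sit.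

The compounds shown leave open whether other amines on the same chain, such as morpholine or dimethylamine, would fare like 4-methylpiperidin-1-yl. They also leave open whether a longer chain, or any core beyond these two, would give the same result.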